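Two Methoxy Groups Replace a Methyl on the Anilino Ring

This account rests on a few compounds, and the source may have more. Where it says the series, first, only, none or still open, it means among the compounds named here.

Measured compounds in a functional assay on PC-3 cells (Homo sapiens) for cytotoxicity, read by MTT assay, with a stated time of 72 h; on this read-out lower numbers stand for stronger inhibition and higher numbers for weaker inhibition:
compound 1 `COc1ccccc1Nc1nc(SCc2ccc(C(F)(F)F)cc2)nc2ccccc12` — 14100 nM
compound 2 `Cc1ccc(Nc2nc(SCc3ccc(C(F)(F)F)cc3)nc3ccccc23)cc1` — 21100 nM

Compound 1 and compound 2 share one core and differ only in the group on a nitrogen on an aromatic ring: 2-methoxyphenyl in compound 1, 4-methylphenyl in compound 2. Going by the values given here, the step of a 1.5-fold higher number from compound 1 to compound 2 (0.18 log units; within the scatter) is the only measured step, and it lies within the scatter, so the two numbers cannot be told apart; compound 2 is simply the one of the two with the larger number on the sheet.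

Compound 3 `COc1ccc(Nc2nc(SCc3ccc(C(F)(F)F)cc3)nc3ccccc23)cc1OC` is not yet measured. It carries 3,4-dimethoxyphenyl in place of 4-methylphenyl on a nitrogen on an aromatic ring. Among the compounds with values here, two methoxy groups thus enter where compound 1 had one; the single measured step says that swapping between a methoxyphenyl and a methylphenyl at this place moved the number by no more than the scatter. On that basis no change beyond the scatter is expected in this assay, and compound 3 is estimated to give 18000 nM, within 7000 nM to 45000 nM, a step of a 1.2-fold lower number from compound 2 to compound 3 (0.07 log units; within the scatter) that is expected to stay within the usual scatter.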

Compound 3, half-maximal inhibitory concentration: 14100 nM
Estimate against measurement, compound 3: 1.3-fold (0.11 log units) above; the range from low to high includes it.
By their numbers in this assay, from the lowest: compounds 1, 3 and 2 (each within the scatter of the next).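

In this assay, putting 3,4-dimethoxyphenyl in place of 4-methylphenyl on the nitrogen gives a 1.5-fold lower number from compound 2 to compound 3 (0.18 log units; within the scatter), and putting it in place of 2-methoxyphenyl gives no change at the digits printed from compound 1 to compound 3 (within the scatter). Going by these compounds alone, the entering group carries 10 heavy atoms and 2 hydrogen-bond acceptors where 4-methylphenyl carries 7 heavy atoms and 0 acceptors, yet this larger difference in the group, like the first swap between a methoxyphenyl and a methylphenyl, brings no step beyond the scatter, so the three compounds cannot be told apart at this position. Nothing available here accounts for how closely these numbers sit together.

As far as these compounds go, all three groups are phenyl rings bearing only methyl or methoxy, so it stays open whether a phenyl ring with an amine or a carboxylic acid, or a longer chain on the nitrogen in place of the ring, would move the number beyond the scatter. From the compounds shown here alone, it also stays open whether the three compounds would remain this close on any read-out other than this assay.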